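The compounds below may be only part of what the source reports. "The series", "measured", "known", "first", "only" and "open" are said of these compounds alone.

Of the compounds shown here, three have been measured in an assay on ileum with muscarinic acetylcholine receptor M3 (Cavia porcellus) as the target; a higher number here means a weaker inhibitor, a lower number a stronger inhibitor. Compound 1 `Cc1nccn1C(C)CC(C(N)=O)(c1ccccc1)c1ccccc1` gives 16.9 nM. Compound 2 `Cc1nccn1CCC(O)(c1ccccc1)c1ccccc1` gives 16.7 nM. Compound 3 `Cc1nccn1CCC(CO)(c1ccccc1)c1ccccc1` gives 25.4 nM. Going by the values given here, only one measured pair differs in a single place, and there a 1.5-fold higher number from compound 2 to compound 3 (0.18 log units; within the scatter). Compound 3 thus carries the highest of the three numbers, but both other values lie within the scatter of it, so no order among the three can be read from what has been measured.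

Compound 4 `Cc1nccn1CCC(C(=O)N(C)C)(c1ccccc1)c1ccccc1` has not yet been measured. It differs from compound 3 in one place: dimethylcarbamoyl in place of hydroxymethyl on a saturated chain carbon bound to two aromatic carbons and a saturated chain carbon. Among the compounds with values here, the only measured step at that position, from compound 2 to compound 3, stayed within the scatter, and compound 1, which carries yet another group at that position together with a change on the chain, gives 16.9 nM, again close to compound 3. Within the data shown here, nothing measured so far points to a large move in either direction in this assay. The step of a 1.1-fold higher number from compound 3 to compound 4 (0.04 log units; within the scatter) is therefore expected to stay within the scatter, with a slight lean toward a higher number. Compound 4 is estimated at 28 nM, with a range from 9 nM to 90 nM.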

Compound 4, antagonist equilibrium constant: 258 nM
Compound 4: the middle estimate sits 9.2-fold (0.96 log units) below what was measured; measured number above the stated range.
By their numbers in this assay, from the lowest: compounds 2, 1 and 3 (each within the scatter of the next); then compound 4.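

At the saturated chain carbon bound to two aromatic carbons and a saturated chain carbon, the group carried there can matter a great deal in this assay: dimethylcarbamoyl in place of hydroxymethyl gives a 10-fold higher number from compound 3 to compound 4 (1.01 log units; beyond the scatter) and dimethylcarbamoyl in place of hydroxy gives a 15-fold higher number from compound 2 to compound 4 (1.19 log units; beyond the scatter) while the earlier step at this place, a 1.5-fold higher number from compound 2 to compound 3 (0.18 log units; within the scatter), had shown no change beyond the scatter. Among these three groups, then, hydroxy and hydroxymethyl cannot be told apart, and dimethylcarbamoyl, which has more heavy atoms and no hydrogen-bond donor, alone stands apart. No outside evidence bears on this result, so it remains a measured difference without an explanation.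

On these data alone, it remains open whether the step follows the carbonyl or the two methyl groups on the nitrogen, a question that a methylcarbamoyl or a plain carbamoyl group on the chain of compound 4 would address. As far as these compounds go, how a carboxylic acid or an aminomethyl group would read at this place in this assay is equally open.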